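Phenoxy in place of benzyl: an expected dose

A few compounds are considered here, and "the series" means these few. Any claim that something is new, unique, unknown or untested is made for them only; others in the source may bear on it.

Of the compounds shown here, three have so far been measured in a functional assay on the whole organism for inhibition, with Rattus norvegicus as the target; on this read-out higher numbers stand for an effect only at larger amounts of compound and lower numbers for an effect already at smaller amounts. Compound 1 (`CC(C)(C)c1ccc(OC(Cc2ccc(Cl)cc2)C(=O)O)cc1`) gives 25 mg/kg, and compound 2 (`CCCc1ccc(CC(C)(Oc2ccc(C(C)C)cc2)C(=O)O)cc1`) gives 0.5 mg/kg. Compound 3 (`CC(Cc1ccc(Cl)cc1)(Oc1ccc(Cc2ccccc2)cc1)C(=O)O`) gives 1 mg/kg, which lies within the usual scatter of compound 2 and, by a margin well beyond the scatter, at a smaller dose than compound 1.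

The unmeasured compound 4 (`CC(Cc1ccc(Cl)cc1)(Oc1ccc(Oc2ccccc2)cc1)C(=O)O`) is compound 3 with phenoxy in place of benzyl on an aromatic carbon, para to a large group (phenoxy in place of benzyl on an aromatic carbon). Going by the values given here, no two measured compounds differ in one place only, so the data hold no direct measure of a change of this kind. The nearest guide is loose: compound 2 at 0.5 mg/kg and compound 3 at 1 mg/kg stand within the scatter of each other even though they differ in more than one place. On that slender basis, no shift beyond the scatter is expected in this assay in either direction. The estimated step is a 1.3-fold lower number from compound 3 to compound 4 (0.10 log units; within the scatter) and it is expected to stay within the scatter. For compound 4 the estimated value is 0.8 mg/kg, with the expected range running from 0.25 mg/kg to 3 mg/kg when the measurement is made.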

Compound 4, dose for half-maximal effect: < 1 mg/kg
Compound 4 ended at the assay's limit; the forecaster's own chance of this, stated with the estimate: 5%; the middle value is on the limit's open side.
By their numbers in this assay, from the lowest: compounds 2 and 3 (each within the scatter of the next); then compound 1.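

In this assay compound 4 gives < 1 mg/kg, which is a limit of the assay and not a number. This is the first change in one place among the compounds shown, and it indicates that on this aromatic carbon, para to a large group, phenoxy can take the place of benzyl, bringing in oxygen where benzyl holds carbon only, with no rise in the dose needed: the result is a number no higher from compound 3 to compound 4 (the limit leaves the size open). How large that step is cannot be read, because the result rests on the assay's limit: the limit of < 1 mg/kg in this assay, at which 1 of the 4 values shown sits.

The compounds shown therefore leave open whether phenoxy truly lowers the dose relative to benzyl or merely matches it, and they give no other one-place change at this aromatic carbon against which this swap could be set. They also leave open how an amine, a nitrile or a longer chain would fare on the same carbon, and how an amide in place of the carboxylic acid would read in this assay.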